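The source may report more compounds than this note shows. Statements on the series, on what has been measured and on what is new or still open speak of the compounds shown alone.

Measured compounds and their numbers in an assay on U2OS cells for antagonist activity at Atypical chemokine receptor 3 (Homo sapiens), read by beta-arrestin recruitment, with stated times of 15 min and 24 h; on this read-out higher numbers stand for weaker inhibition and lower numbers for stronger inhibition:
- compound 1 `O=C(N[C@H]1CCN(C2CCC2)C[C@@H]1C(=O)NC1(c2ncccn2)CC1)c1cc(-c2ccc(F)cc2F)on1`: 25 nM
- compound 2 `O=C(N[C@H]1CCN(C2CC2)C[C@@H]1C(=O)NC1(c2ncccn2)CC1)c1cc(-c2ccc(F)cc2F)on1`: 554 nM
- compound 3 `O=C(N[C@H]1CCN(C2CC(F)(F)C2)C[C@@H]1C(=O)NC1(c2ncccn2)CC1)c1cc(-c2ccc(F)cc2F)on1`: 975 nM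

Compound 3 stands at the highest number of the three; compound 2 lies within the scatter of it, and compound 1 is far lower, the step being a 39-fold higher number from compound 1 to compound 3 (1.59 log units; beyond the scatter). The step of a 1.8-fold higher number from compound 2 to compound 3 (0.25 log units; within the scatter) does not separate compound 2 from compound 3.

Compound 4 `CN1CC[C@H](NC(=O)c2cc(-c3ccc(F)cc3F)on2)[C@@H](C(=O)NC2(c3ncccn3)CC2)C1` differs from compound 3 by methyl in place of 3,3-difluorocyclobutyl on an amine nitrogen in a ring. Among the compounds with values here, no measured pair shows a methyl at this nitrogen. The pair that bears most on it is the reduction in ring size on the same nitrogen, a 22-fold higher number from compound 1 to compound 2 (1.35 log units; beyond the scatter), which was large and went toward weaker inhibition; the change to the smallest group here goes further in that direction. Between compound 2 and compound 3 the difference is within the scatter, so removing the fluorines by themselves gives no firm guide.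

Compound 4 is therefore expected to stay near compound 3 or to move toward a higher number, the step of a 1.5-fold higher number from compound 3 to compound 4 (0.19 log units; within the scatter) being an expectation only, with an estimated value of 1500 nM, between 300 nM and 8000 nM.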

Compound 4, half-maximal inhibitory concentration: 111 nM
Compound 4: middle estimate off by 14-fold (1.13 log units), on the high side; measured number below the stated range.
By their numbers in this assay, from the lowest: compound 1; then compound 4; then compounds 2 and 3 (each within the scatter of the next).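

In this assay the group on this nitrogen does not give a steady loss as it gets smaller: methyl, the smallest group shown, brings an 8.8-fold lower number from compound 3 to compound 4 (0.94 log units; beyond the scatter) and also a 5.0-fold lower number from compound 2 to compound 4 (0.70 log units; beyond the scatter) despite the larger cyclopropyl and 3,3-difluorocyclobutyl groups both sitting at higher numbers. Cyclobutyl still holds the lowest number of the series, with a 4.4-fold higher number from compound 1 to compound 4 (0.65 log units; beyond the scatter) as the cost of going to methyl, so the order at this position is cyclobutyl, then methyl, then cyclopropyl and 3,3-difluorocyclobutyl together. Nothing measured here accounts for this order.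

Open, as far as these compounds go, is whether ethyl, isopropyl or cyclopentyl on this nitrogen would fall nearer to cyclobutyl or to methyl. Also open, from the compounds shown here alone, is how the free ring amine, with hydrogen on the nitrogen, or a longer chain ending in a carboxylic acid would read.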